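The source may hold more compounds than are shown below. What is called first, only, known or untested is meant among the compounds shown, and "the series" means these compounds.

The measured compounds, all read in an assay on isolated protein for inhibition of matrix metalloproteinase-9 (Homo sapiens), read by fluorescence, with a stated time of 30 min; a higher number here means a weaker inhibitor, a lower number a stronger inhibitor:
compound 1 `Cc1ccc(S(=O)(=O)N(CCN=[N+]=[N-])[C@@H](C(=O)NO)C(C)C)cc1`, 4 nM;
compound 2 `COc1ccc(S(=O)(=O)N(CCn2cc(COCCOCCOCCOCCOCCF)nn2)[C@@H](C(=O)NO)C(C)C)cc1`, 2 nM;
compound 3 `COc1ccc(S(=O)(=O)N(CCn2cc(CCCCOc3cccnc3F)nn2)[C@@H](C(=O)NO)C(C)C)cc1`, 0.3 nM.

Compound 3 stands lowest of the three, and its separation from both compound 2 and compound 1 lies beyond the scatter. Compound 4 `COc1ccc(S(=O)(=O)N(CCn2cc(CN(C)S(=O)(=O)c3ccc(F)cc3)nn2)[C@@H](C(=O)NO)C(C)C)cc1` differs from compound 3 by a group of 12 heavy atoms (7 carbon, 1 nitrogen, 2 oxygen, 1 fluorine, 1 sulfur; one six-membered aromatic ring of carbon only) in place of a group of 11 heavy atoms (8 carbon, 1 nitrogen, 1 oxygen, 1 fluorine; one six-membered aromatic ring with 1 hetero atom), on a saturated chain carbon bound to an aromatic carbon. Going by the values given here, no step between measured compounds matches this change, so its size is open; compound 2 at 2 nM and compound 3 at 0.3 nM show that this part of the molecule moves the number, and a shift upward from compound 3 is the more likely direction. Compound 4 is therefore expected to give 1 nM, within 0.3 nM to 4 nM. The expected step from compound 3 to compound 4 is a 3.3-fold higher number from compound 3 to compound 4 (0.52 log units; beyond the scatter), a modest one.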

Compound 4, half-maximal inhibitory concentration: 3 nM
For compound 4 the middle estimate is 3.0-fold (0.48 log units) below the measured one; the range from low to high includes it.
By their numbers in this assay, from the lowest: compound 3; then compounds 2, 4 and 1 (each within the scatter of the next).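

In this assay the group with a six-membered aromatic ring of carbon only, in place of the group with a six-membered aromatic ring with 1 hetero atom, gives a 10-fold higher number from compound 3 to compound 4 (1.00 log units; beyond the scatter) and so shows, as a single change, that this place responds to such an exchange. The two groups match in their counts of hydrogen-bond donors and acceptors, and neither carries a net charge, so these counts do not separate them. No measurement here accounts for the step. 

As far as these compounds go, the exchange alters the ring and the chain joining it together, so the part that carries the step stays open. From the compounds shown here alone, how a simple amine or a carboxylic acid in this place would read also remains open.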